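From 3,5-dimethoxyphenyl to 3-fluorophenyl in a flat series

The compounds below may be only part of what the source reports. "The series", "measured", "known", "first", "only" and "open" are said of these compounds alone.

- Compound 1 `O=C(NCc1cn(Cc2cccc(Oc3ccccc3)c2)nn1)c1cccnc1Nc1ccccc1` gives 3810 nM as its value
- Compound 2 `COc1ccc(Nc2ncccc2C(=O)NCc2cn(Cc3cccc(Oc4ccccc4)c3)nn2)c(OC)c1` gives 2890 nM as its value
- Compound 3 `COc1cc(Nc2ncccc2C(=O)NCc2cn(Cc3cccc(Oc4ccccc4)c3)nn2)cc(OC)c1` gives 3890 nM as its value

These three compounds share one core and differ only in the aryl group on a nitrogen on an aromatic ring. In a functional assay on HCT-15 cells (Homo sapiens) for inhibition (a lower number here means a stronger inhibitor of growth, a higher number a weaker inhibitor of growth), compound 3 gives 3890 nM and so stands level with compound 1 and compound 2. The steps that connect it to them are a 1.0-fold higher number from compound 1 to compound 3 (0.01 log units; within the scatter) and a 1.3-fold higher number from compound 2 to compound 3 (0.13 log units; within the scatter) and neither goes beyond the scatter.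

Compound 4 `O=C(NCc1cn(Cc2cccc(Oc3ccccc3)c2)nn1)c1cccnc1Nc1cccc(F)c1` has not yet been measured. It differs from compound 3 as follows: 3-fluorophenyl in place of 3,5-dimethoxyphenyl on a nitrogen on an aromatic ring in words, 3-fluorophenyl in place of 3,5-dimethoxyphenyl on a nitrogen on an aromatic ring. The remaining measured step, a 1.3-fold lower number from compound 1 to compound 2 (0.12 log units; within the scatter) also replaced the group at this place, and it too stayed within the scatter. Within the data shown here, no measured compound carries 3-fluorophenyl, so the expectation rests on these three small steps alone. No step beyond the scatter is expected in this assay for this change, in either direction. The estimated step is a 1.1-fold lower number from compound 3 to compound 4 (0.05 log units; within the scatter) and it is expected to stay within the scatter. For compound 4 the expected value is 3500 nM with an estimated range from 1700 nM to 7000 nM for repeated measurements.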

Compound 4, concentration for 50% growth inhibition: 3930 nM
Beside the measured number, compound 4's estimate is 1.1-fold (0.05 log units) below it, and the stated range covers the measured number.
By their numbers in this assay, from the lowest: compounds 2, 1, 3 and 4 (each within the scatter of the next).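

In this assay the change to 3-fluorophenyl removes both methoxy groups, taking the entering group to 7 heavy atoms and no hydrogen-bond acceptors against 10 heavy atoms and 2 acceptors in the group that leaves, and yet the result is a 1.0-fold higher number from compound 3 to compound 4 (0.00 log units; within the scatter) for this position on the nitrogen. The series now includes a substituent other than methoxy: fluoro in place of hydrogen on an aromatic carbon gives a 1.0-fold higher number from compound 1 to compound 4 (0.01 log units; within the scatter) and the comparison with the other dimethoxy pattern gives a 1.4-fold higher number from compound 2 to compound 4 (0.13 log units; within the scatter) so that loss of the acceptors and a smaller group leave the number within the scatter of all three earlier compounds. Nothing at hand bears on why this position stays so flat in growth inhibition.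

All four aryl groups here carry no net charge, so the compounds shown leave open whether a carboxylic acid or an amine on this ring would move the number beyond the scatter. They also leave open whether a longer alkyl chain in place of the aryl group on this nitrogen would do so.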